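This account rests on a few compounds, and the source may have more. Where it says the series, first, only, none or still open, it means among the compounds named here.

In an ADME assay on MDCK cells (Canis lupus familiaris) for cytotoxicity, read by MTT assay, with a stated time of 48 h (on this read-out lower numbers stand for higher toxicity in this test and higher numbers for lower toxicity in this test), compound 1 `COC(=O)[C@@H](NC(=O)CSc1nc(-c2ccccc2)cc(-c2ccc(C)cc2)c1C#N)C(C)C` gives 210000 nM. Compound 2 `COC(=O)[C@H](CCCNC(=N)N)NC(=O)CSc1nc(-c2ccccc2)cc(-c2ccc(C)cc2)c1C#N` gives > 250000 nM, which is a limit. Compound 3 `COC(=O)CC[C@H](NC(=O)CSc1nc(-c2ccccc2)cc(-c2ccc(C)cc2)c1C#N)C(=O)OC` gives > 250000 nM, also a limit and not a number. Compound 3 thus stands with compound 2 at the limit of > 250000 nM in this assay, at which 2 of the 3 values shown sit.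

Compound 4 `Cc1ccc(-c2cc(-c3ccccc3)nc(SCC(=O)O)c2C#N)cc1`, not yet measured, carries hydroxy in place of (1,3-bis(methoxycarbonyl)propyl)amino on a carbonyl carbon.

The measured steps bear on this only indirectly, since each changes the group on a saturated chain carbon and none removes the departing group. The series shows an at least 1.1-fold higher number from compound 1 to compound 2 (0.07 log units; that floor lies within the scatter) and an at least 1.1-fold higher number from compound 1 to compound 3 (0.07 log units; that floor lies within the scatter), while a step that the two limits leave unreadable from compound 2 to compound 3 cannot be sized. No measured change in this group gives a step beyond the scatter, so none is expected in this assay, and no direction can be assigned with confidence. The expected step is an at least 1.0-fold lower number from compound 3 to compound 4 (0.03 log units; that floor lies within the scatter). With compound 1 at 210000 nM as the one numerical anchor, the expectation stays close to that value. For compound 4 the estimate is 230000 nM, with an expected range of 100000 nM to 450000 nM.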

Compound 4, half-maximal cytotoxic concentration: > 250000 nM
Compound 4 gave a limit, no number (the forecaster's own chance of this, stated with the estimate: 50%); middle value at least 1.0-fold (0.03 log units) from the limit.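

In this assay, compound 4 gives > 250000 nM, which is a limit and not a number. Going by these compounds alone, the earlier compounds varied only the group on a saturated chain carbon, whereas here the whole (1,3-bis(methoxycarbonyl)propyl)amino group leaves the carbonyl carbon for hydroxy, and the one readable comparison with a numbered compound gives an at least 1.1-fold higher number from compound 1 to compound 4 (0.07 log units; that floor lies within the scatter). The step from compound 3 to compound 4 cannot be read, as both values are limits, and the series gathers further at a single limit: the limit of > 250000 nM in this assay, at which 3 of the 4 values shown sit.

From the compounds shown here alone, only compound 1 carries a number, so the size of any effect at this carbonyl carbon stays unknown. Also open, going by these compounds, is whether a simple amine such as benzylamine, or a methyl ester, on this carbonyl carbon would give a number rather than a limit.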